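This account rests on a few compounds, and the source may have more. Where it says the series, first, only, none or still open, it means among the compounds named here.

Working notes on the series.

Compound 2 `Cc1ccc(-c2cs/c(=N/NC(=O)CSc3nnnn3C)n2-c2ccccc2)cc1` is the starting point of this step. In a functional assay on C6 cells (Rattus norvegicus) for cytotoxicity, read by MTT assay, with a stated time of 24 h, tested at 12 ug/mL (a lower number here means a stronger effect, a higher number a weaker effect of the compound at the concentration tested), compound 2 gives 68.8%, which places it as the lowest of the two numbers at hand, its nearest neighbour being compound 1 `Cc1ccc(-c2cs/c(=N/NC(=O)CSc3nncn3C)n2-c2ccccc2)cc1`, which in this assay gives 72%. Within the data shown here, the only measured step in the set, a number 3.2 percentage points lower from compound 1 to compound 2 (within the scatter), concerns the group on the sulfur and stays within the scatter.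

Compound 3 `Cn1nnnc1SCC(=O)N/N=c1/scc(-c2ccc([N+](=O)[O-])cc2)n1-c1ccccc1` is not yet measured. It differs from compound 2 by nitro in place of methyl on an aromatic carbon. Among the measured compounds shown here, the measured step from compound 1 to compound 2 touches a different part of the molecule and therefore says little about this change; no measured pair in the set carries a nitro in place of methyl, so there is no direct precedent for the step. Given that the one step available is within the scatter, the expected step of a number 0.2 percentage points higher from compound 2 to compound 3 (within the scatter) for compound 3 is none beyond the scatter. Compound 3 is accordingly estimated at 69% in this assay, with a range from 52% to 86%.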

Compound 3, a percentage reported as activity, at one concentration (the size of the read-out at that concentration, not a potency): 76.2%
The estimate for compound 3 lay 7.2 percentage points below the measured number; the range from low to high includes it.
By their numbers in this assay, from the lowest: compounds 2, 1 and 3 (each within the scatter of the next).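

Among these compounds, the first measured change at this position, 4-nitrophenyl in place of 4-methylphenyl, gives in this assay a number 7.4 percentage points higher from compound 2 to compound 3 (within the scatter). Among the compounds shown here, until now, the only measured step concerned the group on the sulfur; this one shows that, with 1-methyl-1H-tetrazol-5-yl held on the sulfur, the position on the six-membered aromatic ring, para to a large group, takes a nitro with its additional heavy atoms and hydrogen-bond acceptors in place of a methyl without a step beyond the scatter. Nothing at hand bears on what lies behind this step.

It remains open whether an amine, a carboxylic acid or a chlorine at this position would give a step beyond the scatter, since methyl and nitro are the only two groups shown there. From the compounds shown here alone, it is also open whether the same exchange of methyl for nitro would read alike with 4-methyl-4H-1,2,4-triazol-3-yl on the sulfur, and whether a longer chain between the sulfur and the carbonyl would alter the picture in this assay.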